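This account rests on a few compounds, and the source may have more. Where it says the series, first, only, none or still open, it means among the compounds named here.

Measured in a functional assay on HeLa cells (Homo sapiens) for antiproliferative activity, read by CCK-8 assay, with a stated time of 72 h, tested at 2 uM; a higher number here means a stronger effect of the compound at the concentration tested, a lower number a weaker effect:
compound 1 `Nc1ccccc1NC(=O)c1ccc(CSC(=S)N2CCc3ccccc32)cc1` gives 38%
compound 2 `Nc1ccccc1NC(=O)c1ccc(CSC(=S)N2CCN(c3cccnc3)CC2)cc1` gives 66.2%
compound 3 `COc1ccc(N2CCN(C(=S)SCc3ccc(C(=O)Nc4ccccc4N)cc3)CC2)cc1` gives 39.4%

Compound 1 holds the lowest of the three numbers: compound 3 lies within the scatter of it, while compound 2 stands clearly higher. Going by the values given here, the single one-place step measured so far, a number 26.8 percentage points lower from compound 2 to compound 3 (beyond the scatter), swaps the ring on an amine nitrogen in a ring, 4-methoxyphenyl in place of pyridin-3-yl, and the pyridinyl partner carries the higher number in that pair.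

Compound 4 `CN(Cc1ccncc1)C(=S)SCc1ccc(C(=O)Nc2ccccc2N)cc1` differs from compound 1 at the thiocarbonyl carbon: methyl((pyridin-4-yl)methyl)amino in place of 2,3-dihydro-1H-indol-1-yl on a thiocarbonyl carbon. Among the compounds with values here, no measured step alters that position, so the step from compound 2 to compound 3 bears on it only loosely, through the entry of a pyridine ring, which went with the larger number there. An upward move is therefore more likely than a downward one, but its size is uncertain and may stay within the scatter.

Compound 4 is expected to give 46%, with a range from 28% to 66%. The estimated step, a number 8 percentage points higher from compound 1 to compound 4 (within the scatter), is expected to be small, within the scatter.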

Compound 4, a percentage reported as inhibition, at one concentration (the size of the read-out at that concentration, not a potency): 29.5%
Compound 4: middle estimate off by 16.5 percentage points, on the high side; the measured number falls inside the stated range.
By their numbers in this assay, from the lowest: compounds 4, 1 and 3 (each within the scatter of the next); then compound 2.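

Going by these compounds alone, this is the first step read directly on the thiocarbonyl carbon: in this assay, a number 8.5 percentage points lower from compound 1 to compound 4 (within the scatter), so exchanging 2,3-dihydro-1H-indol-1-yl for methyl((pyridin-4-yl)methyl)amino leaves no change that can be told from the scatter. A pyridine ring in this group therefore does not go with a larger number in every case: the link suggested by the step in which a number 26.8 percentage points lower from compound 2 to compound 3 (beyond the scatter) does not hold for compound 4, which carries such a ring and stays within the scatter of compound 1. Nothing on hand explains either step.

Still open, going by these compounds, is whether a plain dimethylamino group on the thiocarbonyl carbon would give a number in the same range. Also open, on these data alone, is what a longer chain in place of the methyl in methyl((pyridin-4-yl)methyl)amino would do.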